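Swapping the aryl group on the amine-bearing chain carbon

This account rests on a few compounds, and the source may have more. Where it says the series, first, only, none or still open, it means among the compounds named here.

Three compounds share one core and differ only in the aromatic group attached to a saturated chain carbon bound to an amine nitrogen. Compound 1 `CC(C)(C)c1ccc(CNCCCNS(=O)(=O)c2cc(C(F)(F)F)cc(C(F)(F)F)c2)cc1` gives 2500 nM in a functional assay on BE(2)-C cells (Homo sapiens) for inhibition, read by MTT assay, with a stated time of 72 h; a higher number here means a weaker inhibitor of growth, a lower number a stronger inhibitor of growth. Compound 2 `O=S(=O)(NCCCNCc1ccc(Cl)c(Cl)c1)c1cc(C(F)(F)F)cc(C(F)(F)F)c1` gives 2900 nM in this assay, and compound 3 `O=S(=O)(NCCCNCc1cccc2ccccc12)c1cc(C(F)(F)F)cc(C(F)(F)F)c1` gives 2700 nM in this assay. Compound 3 thus stands second highest of the three numbers, with compound 2 nearest and compound 1 furthest, both separations within the scatter. Compound 4 `COc1ccc(CNCCCNS(=O)(=O)c2cc(C(F)(F)F)cc(C(F)(F)F)c2)cc1` carries the change (4-methoxyphenyl in place of naphthalen-1-yl on a saturated chain carbon bound to an amine nitrogen). Going by the values given here, the steps that bear on this are the other aryl swaps at the same place: a 1.2-fold higher number from compound 1 to compound 2 (0.06 log units; within the scatter), a 1.1-fold higher number from compound 1 to compound 3 (0.03 log units; within the scatter) and a 1.1-fold lower number from compound 2 to compound 3 (0.03 log units; within the scatter). Each of them stayed within the scatter, so another aryl swap at this place is expected to give no step beyond the scatter in this assay, which means an expected no change at the digits printed from compound 3 to compound 4 (within the scatter). Compound 4 is therefore estimated at 2700 nM, with an expected range from 1200 nM to 6000 nM.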

Compound 4, concentration for 50% growth inhibition: 2800 nM
For compound 4 the middle estimate is 1.0-fold (0.02 log units) below the measured one; the measured number falls inside the stated range.
By their numbers in this assay, from the lowest: compounds 1, 3, 4 and 2 (each within the scatter of the next).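

Going by these compounds alone, compound 4 puts the first oxygen-bearing aryl group of this set at the saturated chain carbon bound to an amine nitrogen, and it replaces the two aromatic rings of naphthalen-1-yl with one, yet this assay gives a 1.0-fold higher number from compound 3 to compound 4 (0.02 log units; within the scatter) for this change. Set against the other two aryl groups, it gives a 1.0-fold lower number from compound 2 to compound 4 (0.02 log units; within the scatter) and a 1.1-fold higher number from compound 1 to compound 4 (0.05 log units; within the scatter) in this assay, so this position has now tolerated a methoxy group as well as tert-butyl, two chlorines and a second fused ring without any step beyond the scatter. No available evidence says why these four compounds read alike.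

As far as these compounds go, whether an amine or a carboxylic acid on the aromatic ring would also leave the number within the scatter remains open. So does the effect of replacing the aromatic group with a saturated ring such as cyclohexyl, or of a longer chain in the shared core.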